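Swapping a Urea Substituent: From Compound 3 to Compound 4

A few compounds are considered here, and "the series" means these few. Any claim that something is new, unique, unknown or untested is made for them only; others in the source may bear on it.

Three compounds sharing one core have been examined in a functional assay on U-87MG ATCC cells for antiproliferative activity against U-87 MG (Homo sapiens), read by MTT assay, with a stated time of 72 h; a lower number here means a stronger inhibitor, a higher number a weaker inhibitor. Compound 1 `CCN(CC)CCNC(=O)Nc1nc2ccc(-c3cnc(OC)c(NS(=O)(=O)c4ccc(F)cc4)c3)cc2s1` gives 390 nM. Compound 2 `CCCNc1nc2ccc(-c3cnc(Cl)c(NS(=O)(=O)c4ccc(F)cc4)c3)cc2s1` gives "not determined" (no result reported), so no number is available for it. Compound 3 `O=C(Nc1nc2ccc(-c3cnc(Cl)c(NS(=O)(=O)c4ccc(F)cc4)c3)cc2s1)NC1CC1` gives 1720 nM, the highest of the two numbers available, which places it well beyond the usual scatter from compound 1.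

Compound 4 `CCN(CC)CCNC(=O)Nc1nc2ccc(-c3cnc(Cl)c(NS(=O)(=O)c4ccc(F)cc4)c3)cc2s1` is the next structure. Compared with compound 3, the change is 2-(diethylamino)ethyl in place of cyclopropyl on an amide-type nitrogen. Compound 1 carries this same 2-(diethylamino)ethyl group and shows the lower of the two recorded numbers, although compound 1 and compound 4 also differ elsewhere. In this assay a moderate step toward a lower number, a 2.6-fold lower number from compound 3 to compound 4 (0.42 log units; beyond the scatter), is expected. Compound 4 is estimated at 650 nM, within 250 nM to 1700 nM.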

Compound 4, half-maximal inhibitory concentration: 1390 nM
Estimate against measurement, compound 4: 2.1-fold (0.33 log units) below; low and high end bracket the measured number.
By their numbers in this assay, from the lowest: compound 1; then compounds 4 and 3 (each within the scatter of the next).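

Replacing cyclopropyl with 2-(diethylamino)ethyl on the amide-type nitrogen gives a 1.2-fold lower number from compound 3 to compound 4 (0.09 log units; within the scatter), so with chloro kept on the aromatic carbon, this swap does not separate the two compounds. Going by these compounds alone, the other single change, chloro in place of methoxy on an aromatic carbon, gives a 3.6-fold higher number from compound 1 to compound 4 (0.55 log units; beyond the scatter), so of these two changes only this one produces a step beyond the scatter. No evidence here explains either result.

Going by these compounds, whether the urea swap would also make so little difference with methoxy on that aromatic carbon remains open. So does the effect of a longer alkyl chain or a carboxylic acid on the amide-type nitrogen.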